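A Methyl Group on the Core and Expected Oral Exposure

The source may report more compounds than this note shows. Statements on the series, on what has been measured and on what is new or still open speak of the compounds shown alone.

Of the compounds shown here, two of one series have been measured in an ADME assay on the whole organism (Rattus norvegicus, strain Wistar) for pharmacokinetics, read by LC-MS, with a stated time of 8 h, at a dose of 10 mg/kg by the oral route; on this read-out higher numbers stand for higher exposure at the dose given and lower numbers for lower exposure. Compound 1 `N=C(N)NCCC[C@H](NC(=O)c1ccc(C(c2ccc(Cl)cc2)c2ccc(Cl)cc2)s1)C(=O)O` gives 814 ng.h/mL. Compound 2 `N=C(N)NCCC[C@H](NC(=O)c1ccc(C(c2ccccc2)c2ccccc2)s1)C(=O)O` gives 436 ng.h/mL, a number that lies within the usual scatter of the value for compound 1, so the two cannot be told apart on this read-out. Among the compounds with values here, no step between measured compounds is available for the change considered here.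

Compound 3 `Cc1cc(C(c2ccccc2)c2ccccc2)sc1C(=O)N[C@@H](CCCNC(=N)N)C(=O)O` differs from compound 2 in one place: methyl in place of hydrogen on an aromatic carbon. Within the data shown here, with no measured step of this kind to lean on, and with compound 2 at 436 ng.h/mL as the starting point, he expects no step beyond the scatter in this assay, in either direction. The exposure of compound 3 is therefore estimated at 450 ng.h/mL, with a range from 150 ng.h/mL to 1300 ng.h/mL, which corresponds to an expected step of a 1.0-fold higher number from compound 2 to compound 3 (0.01 log units; within the scatter).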

Compound 3, area under the concentration-time curve: 90 ng.h/mL
Compound 3: the middle estimate sits 5.0-fold (0.70 log units) above what was measured, outside the stated range (below it).
By their numbers in this assay, from the lowest: compound 3; then compounds 2 and 1 (each within the scatter of the next).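

In this assay, methyl in place of hydrogen on an aromatic carbon of the five-membered aromatic ring, next to the ring atom that bears a large group, gives a 4.8-fold lower number from compound 2 to compound 3 (0.69 log units; beyond the scatter) in this series. Within the data shown here, compounds 1 and 2 lie within the scatter of each other and carry no change at this position, so this is the first sign that a single added carbon on the core can move exposure beyond the scatter. Nothing available bears on what lies behind this step.

As far as these compounds go, it remains open whether the step belongs to methyl alone or would also appear with a fluorine, an ethyl group or a methoxy group at this position. From the compounds shown here alone, it is also open whether the same methyl would have a similar effect on the core of compound 1, with its two chlorines.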